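Aryl-alkyne phenoxyacetic acids: carbamoyl to sulfonyl exchange

The compounds below may be only part of what the source reports. "The series", "measured", "known", "first", "only" and "open" are said of these compounds alone.

Measured compounds in an assay on CHO cells for displacement of a labelled ligand from prostaglandin D2 receptor 2 (Homo sapiens), read by scintillation counting; on this read-out lower numbers stand for stronger inhibition and higher numbers for weaker inhibition:
- compound 1 `CN(C)C(=O)c1cccc(C#Cc2cc(Cl)ccc2OCC(=O)O)c1` gives 52 nM
- compound 2 `COc1ccccc1C#Cc1cc(Cl)ccc1OCC(=O)O` gives 190 nM
- compound 3 `CC(C)S(=O)(=O)c1ccc(Cl)c(C#Cc2cc(Cl)ccc2OCC(=O)O)c1` gives 2.9 nM

Compound 1 sits second highest of the three numbers. Compound 2 is its nearest neighbour, with a higher number beyond the scatter; compound 3 stands furthest from it, with a lower number also beyond the scatter. No two of these compounds differ in one place only, so no single step is available and only the values themselves can be compared.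

Compound 4 `CS(=O)(=O)c1cccc(C#Cc2cc(Cl)ccc2OCC(=O)O)c1` has not yet been tested in this assay. It differs from compound 1 by methylsulfonyl in place of dimethylcarbamoyl on an aromatic carbon. The expectation rests on compound 3, whose number of 2.9 nM is the lowest in the set and which also carries a sulfonyl group on the outer ring. Compound 4 is therefore estimated at 15 nM, with a range from 4 nM to 50 nM. The step expected from compound 1 to compound 4 is a 3.5-fold lower number from compound 1 to compound 4 (0.54 log units; beyond the scatter), a lower number beyond the scatter.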

Compound 4, inhibition constant: 15 nM
Compound 4: the middle estimate sits on the measured number at the digits printed; the measured number falls inside the stated range.
By their numbers in this assay, from the lowest: compound 3; then compound 4; then compound 1; then compound 2.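

At this aromatic carbon, meta to a large group, methylsulfonyl in place of dimethylcarbamoyl gives, in this assay, a 3.5-fold lower number from compound 1 to compound 4 (0.54 log units; beyond the scatter). Going by these compounds alone, this is the only single-place step, and it links a sulfonyl group directly to a lower number, which the value of compound 3 alone could not do. The change goes from one hydrogen-bond acceptor to two, but no measurement here bears on why the number moves.

Steps linking compound 2 or compound 3 to the other compounds cannot be read, as each differs from them in more than one place. Also open, going by these compounds, is whether a sulfonamide or a nitrile at this same carbon, or a longer chain on the sulfur, would keep the lower number.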